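Swapping a cyano for a bromo, seen once, tried again

This account rests on a few compounds, and the source may have more. Where it says the series, first, only, none or still open, it means among the compounds named here.

Measured compounds:
Compound 1 `N#Cc1ccc(-c2cs/c(=N/NC(=O)CSc3ncccn3)n2-c2ccccc2)cc1` gives < 3.9 ug/mL, which is a limit of the assay.
Compound 2 `O=C(CSc1ncccn1)N/N=c1/scc(-c2ccc(Br)cc2)n1-c1ccccc1` gives 273 ug/mL.
Compound 3 `Cc1nnc(SCC(=O)N/N=c2/scc(-c3ccc(C#N)cc3)n2-c2ccccc2)s1` gives < 3.9 ug/mL, again a limit of the assay.

All three were tested in an ADME assay on NIH3T3 cells (Mus musculus) for cytotoxicity, read by MTT assay, with a stated time of 24 h; on this read-out higher numbers stand for weaker inhibition and lower numbers for stronger inhibition. Compound 1 and compound 3 both sit at the limit of this assay, so their values are not numbers; only compound 2 has a numerical read-out. Within the data shown here, the one readable step is an at least 70-fold higher number from compound 1 to compound 2 (1.84 log units; beyond the scatter), brought about by the change (bromo in place of cyano on an aromatic carbon). The step that the two limits leave unreadable from compound 1 to compound 3 cannot be sized, because both ends are limits; the two cores differ by 5-methyl-1,3,4-thiadiazol-2-yl in place of pyrimidin-2-yl on a sulfur.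

The unmeasured compound 4 `Cc1nnc(SCC(=O)N/N=c2/scc(-c3ccc(Br)cc3)n2-c2ccccc2)s1` differs from compound 3 by bromo in place of cyano on an aromatic carbon. The place of this change matches word for word the place of the change from compound 1 to compound 2, so it is the same change applied to the other core. Among the measured compounds shown here, the only evidence on its size is the limit of < 3.9 ug/mL in this assay, at which 2 of the 3 values shown sit, together with the single readable step, and that step was large.

For compound 4 the step of an at least 51-fold higher number from compound 3 to compound 4 (1.70 log units; beyond the scatter) is therefore expected to resemble an at least 70-fold higher number from compound 1 to compound 2 (1.84 log units; beyond the scatter), resting on that step alone. The value of compound 4 is estimated at 200 ug/mL, within a range from 40 ug/mL to 500 ug/mL, with the caveat that compound 3 is itself only a limit.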

Compound 4, half-maximal inhibitory concentration: 55 ug/mL
Compound 4: middle estimate off by 3.6-fold (0.56 log units), on the high side; the measured number falls inside the stated range.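

In this assay the change from 4-cyanophenyl to 4-bromophenyl again brings a rise in the number, which means weaker inhibition: an at least 14-fold higher number from compound 3 to compound 4 (1.14 log units; beyond the scatter), so the direction seen on the core of compound 1 carries over to the core of compound 3. Set side by side, the two results read: the same change on two cores in this assay, an at least 70-fold higher number (1.84 log units; beyond the scatter) from compound 1 to compound 2 and an at least 14-fold higher number (1.14 log units; beyond the scatter) from compound 3 to compound 4; the limit leaves it open whether they differ. Compound 3 gives < 3.9 ug/mL, which is a limit of the assay and not a number, so this pair shows the direction of the change but not its exact size, and two cores are too few to make a rule for the whole series.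

From the compounds shown here alone, the swap of pyrimidin-2-yl for 5-methyl-1,3,4-thiadiazol-2-yl on the sulfur can be sized only among the bromo compounds, as a 5.0-fold lower number from compound 2 to compound 4 (0.70 log units; beyond the scatter), while the steps that have a limit at both ends cannot be read, so it remains open how large that swap is among the cyano compounds. Also open, going by these compounds, is whether other groups on the same aromatic carbon, such as a methoxy group or an amine, would give numbers closer to those of the bromo compounds or to those of the cyano compounds.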